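Propyl to isopropyl on the aromatic ring: expected potency

The source may report more compounds than this note shows. Statements on the series, on what has been measured and on what is new or still open speak of the compounds shown alone.

Three compounds of this series have a number in an assay on isolated protein for displacement of a labelled ligand from melanin-concentrating hormone receptor 1 (Homo sapiens); on this read-out higher numbers stand for weaker inhibition and lower numbers for stronger inhibition. Compound 1 `CCCc1ccc(/C=C/C(=O)Nc2ccc3nc(CCC)cc(N)c3c2)cc1` gives 4 nM in this assay. Compound 2 `CC(C)(C)c1cc(N)c2cc(NC(=O)/C=C/c3ccc(C(F)(F)F)cc3)ccc2n1` gives 0.3 nM, and compound 3 `CCCc1cc(N)c2cc(NC(=O)c3ccc(C(F)(F)F)cc3)ccc2n1` gives 10000 nM. Among these three numbers compound 1 holds the second highest: compound 2 lies below it by a gap beyond the scatter, and compound 3 lies far above it, also beyond the scatter. Compounds 2 and 3 each differ from compound 1 in more than one place, so neither gap can be read as the effect of a single change.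

Compound 4 `CCCc1cc(N)c2cc(NC(=O)/C=C/c3ccc(C(C)C)cc3)ccc2n1` is not yet measured. It is built from compound 1 with the same atoms joined differently: isopropyl in place of propyl on an aromatic carbon. Isopropyl replaces propyl on an aromatic carbon of a six-membered aromatic ring of carbon only, para to a large group; cut one bond further out, the change reads 4-propylphenyl to 4-isopropylphenyl.

Going by the values given here, no pair of measured compounds shows this change, so there is no measured step to lean on. In this assay the step from compound 1 is expected to be small, in neither direction beyond the scatter. Compound 4 is therefore estimated at about 5 nM, with a range from 1.5 nM to 15 nM. The step this estimate implies, a 1.3-fold higher number from compound 1 to compound 4 (0.10 log units; within the scatter), is expected to stay within the scatter.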

Compound 4, half-maximal inhibitory concentration: 2.9 nM
Compound 4: middle estimate off by 1.7-fold (0.24 log units), on the high side, within the range that was stated.
By their numbers in this assay, from the lowest: compound 2; then compounds 4 and 1 (each within the scatter of the next); then compound 3.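

In this assay, going by these compounds alone, this is the first comparison that isolates a single change: a 1.4-fold lower number from compound 1 to compound 4 (0.14 log units; within the scatter) lies within the scatter. On this aromatic carbon, para to a large group, the assay therefore does not separate isopropyl from propyl, which gives the series its first direct reading at this position. The earlier compounds shown here could not provide such a reading. Each of them differs from compound 1 in more than one place. Within the data shown here, the comparison records only that the two groups are not distinguished here, and no measurement is available that explains this outcome.

On these data alone, this single pair does not show how far the position tolerates other replacements, so it remains open whether a longer chain, an amine or a carboxylic acid on the same aromatic carbon would stay within the scatter of compound 1. Compound 2 and compound 3 each still differ from compound 4 in more than one place, so the large gaps among these compounds cannot yet be assigned to any single change in the shared core or its substituents.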